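Methoxy substitution on the anilino ring of a thioacetamide series

The compounds below may be only part of what the source reports. "The series", "measured", "known", "first", "only" and "open" are said of these compounds alone.

Measured so far:
- compound 1 `Cc1nc(SCC(=O)Nc2nc(-c3ccc(Cl)cc3)cs2)n(Nc2ccccc2)c1C`, 14500 nM
- compound 2 `Cc1ccc(Nn2c(SCC(=O)Nc3nc(-c4ccccc4)cs3)nc(C)c2C)cc1`, 34400 nM

Two compounds of the shared core have numbers in a functional assay on COLO 205 cells (Homo sapiens) for antiproliferative activity, read by sulforhodamine B assay, with a stated time of 48 h; a lower number here means a stronger inhibitor of growth, a higher number a weaker inhibitor of growth. Compound 1 `Cc1nc(SCC(=O)Nc2nc(-c3ccc(Cl)cc3)cs2)n(Nc2ccccc2)c1C` gives 14500 nM, the lowest of the two; compound 2 `Cc1ccc(Nn2c(SCC(=O)Nc3nc(-c4ccccc4)cs3)nc(C)c2C)cc1` gives 34400 nM, a gap that lies beyond the scatter. For the measured compounds named here, compound 2 differs from compound 1 in more than one place, so no single step between them can be read off; its two values show only that the pair of changes together goes with weaker growth inhibition.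

Compound 3 `COc1ccc(Nn2c(SCC(=O)Nc3nc(-c4ccc(Cl)cc4)cs3)nc(C)c2C)cc1` is not yet measured. It differs from compound 1 by methoxy in place of hydrogen on an aromatic carbon of the six-membered aromatic ring of carbon only, para to a large group; cut one bond further out, anilino becomes (4-methoxyphenyl)amino. Going by the values given here, no measured pair isolates this change, so no direction can be taken from the numbers. With compound 1 at 14500 nM as the only anchor, a step from compound 1 to compound 3 of about a 1.2-fold higher number from compound 1 to compound 3 (0.09 log units; within the scatter) in this assay is expected, within or near the scatter. Compound 3 is estimated at 18000 nM, with a range from 7000 nM to 45000 nM.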

Compound 3, concentration for total growth inhibition: 3550 nM
Compound 3: middle estimate off by 5.1-fold (0.71 log units), on the high side; the whole stated range lies above it.
By their numbers in this assay, from the lowest: compound 3; then compound 1; then compound 2.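

In this assay, methoxy in place of hydrogen on an aromatic carbon of the anilino ring, para to a large group, gives a 4.1-fold lower number from compound 1 to compound 3 (0.61 log units; beyond the scatter), and this step lies beyond the scatter. For the compounds shown here, it is the first change that can be read on its own, since the earlier pair differed in more than one place and could not show whether this ring position matters. The position does respond to substitution, and the 4-methoxyphenyl group goes with stronger growth inhibition than the unsubstituted phenyl, but nothing on hand explains the step.

On these data alone, it remains open whether this step is specific to methoxy or would also be seen with other groups at the same place, such as hydroxyl, ethoxy or dimethylamino. Going by these compounds alone, also open is whether it carries over to compounds without the chlorine of compound 1, because compound 2 differs from compound 1 and compound 3 in more than one place and no step to it can be read.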